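Adding a Second Methyl to the Amino Nitrogen

The source may report more compounds than this note shows. Statements on the series, on what has been measured and on what is new or still open speak of the compounds shown alone.

Compound 1 `OCCOCn1c(Cl)nc2cc(Cl)c(Cl)cc21` gives > 320000 nM in a functional assay on KB cells (Homo sapiens) for inhibition (on this read-out higher numbers stand for weaker inhibition and lower numbers for stronger inhibition), a limit of the assay.
Compound 2 `Nc1nc2cc(Cl)c(Cl)cc2n1COCCO` gives > 100000 nM in this assay, a limit.
Compound 3 `CNc1nc2cc(Cl)c(Cl)cc2n1COCCO` gives > 100000 nM in this assay, a limit.

Compound 3 therefore stands nowhere on a scale: it sits at a limit, and the two other values are limits as well, as the limit of > 100000 nM in this assay, at which 2 of the 3 values shown sit, and the limit of > 320000 nM in this assay, at which 1 of the 3 values shown sits, show. None of the three steps can be read, neither a step that the two limits leave unreadable from compound 1 to compound 2 nor a step that the two limits leave unreadable from compound 1 to compound 3 nor a step that the two limits leave unreadable from compound 2 to compound 3.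

Compound 4 `CN(C)c1nc2cc(Cl)c(Cl)cc2n1COCCO` differs from compound 3 by methyl in place of hydrogen on a nitrogen on an aromatic ring. Going by the values given here, the step most like it is the one from compound 2 to compound 3, which is the same kind of change one stage earlier, and it too is unreadable. Nothing measured here points to a gain or a loss beyond the scatter for compound 4 in this assay. The step is expected to be a step that the limit leaves unreadable from compound 3 to compound 4, which is to say no readable change. Compound 4 is expected to give about 150000 nM, within 40000 nM to 1000000 nM, and most probably to be reported only as a limit again.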

Compound 4, half-maximal inhibitory concentration: > 100000 nM
Compound 4: no number, only a limit (the forecaster's own chance of this, stated with the estimate: 85%); the middle value does not contradict the limit.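

In this assay compound 4 gives > 100000 nM, a limit of the assay, so its steps from compound 1, compound 2 and compound 3 cannot be read. The compounds shown leave open whether amino, methylamino or dimethylamino in place of chloro, or methyl on the nitrogen, changes inhibition at all, as none of the four gives a number.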